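Methylcarbamoyl in place of isopropyl on an aromatic carbon

The source may hold more compounds than are shown below. What is called first, only, known or untested is meant among the compounds shown, and "the series" means these compounds.

Compound 1 `Cc1ccc(N/N=C2\CCC(C)n3c2ncc(C(=O)O)c3=O)cc1`: 280 nM
Compound 2 `CC1CC/C(=N\Nc2ccc([N+](=O)[O-])cc2)c2ncc(C(=O)O)c(=O)n21`: 8900 nM
Compound 3 `CC(C)c1ccc(N/N=C2\CCC(C)n3c2ncc(C(=O)O)c3=O)cc1`: 1200 nM

In a functional assay (mast cells) for inhibition, with Rattus norvegicus as the target (a lower number here means that less compound is needed, a higher number that more compound is needed for the effect), compound 3 stands second highest of the three, above compound 1 and below compound 2. Compound 4 `CNC(=O)c1ccc(N/N=C2\CCC(C)n3c2ncc(C(=O)O)c3=O)cc1` has methylcarbamoyl in place of isopropyl on an aromatic carbon para to a large group (methylcarbamoyl in place of isopropyl on an aromatic carbon). Isopropyl in place of methyl gave a 4.3-fold higher number from compound 1 to compound 3 (0.63 log units; beyond the scatter) and nitro in place of methyl gave a 32-fold higher number from compound 1 to compound 2 (1.50 log units; beyond the scatter) while isopropyl in place of nitro gave a 7.4-fold lower number from compound 2 to compound 3 (0.87 log units; beyond the scatter) at that same place. Within the data shown here, no measured compound carries the new group, so this guide is indirect. Like nitro, the new group holds nitrogen and oxygen, so the expectation leans towards compound 2 at 8900 nM without reaching it. The expected step in this assay is modest: a 2.5-fold higher number from compound 3 to compound 4 (0.40 log units; beyond the scatter) is estimated. Compound 4 is estimated at 3000 nM with 600 nM to 12000 nM as its expected range.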

Compound 4, half-maximal effective concentration: 100000 nM
Compound 4: the middle estimate sits 33-fold (1.52 log units) below what was measured; measured number outside the range, above it.
By their numbers in this assay, from the lowest: compound 1; then compound 3; then compound 2; then compound 4.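

In this assay, methylcarbamoyl gives the highest number of the four groups at this place: in place of isopropyl it gives an 83-fold higher number from compound 3 to compound 4 (1.92 log units; beyond the scatter), in place of nitro it gives an 11-fold higher number from compound 2 to compound 4 (1.05 log units; beyond the scatter), and in place of methyl it gives a 360-fold higher number from compound 1 to compound 4 (2.55 log units; beyond the scatter). Compound 2 therefore no longer marks the top of the series, and holding nitrogen and oxygen does not put a group close to nitro here. Nothing available explains the size of these steps. The compounds shown leave open whether a dimethylcarbamoyl group, which has no amide hydrogen, would behave like methylcarbamoyl, and whether fluorine or hydroxyl would bring the number nearer to that of compound 1.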